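This account rests on a few compounds, and the source may have more. Where it says the series, first, only, none or still open, it means among the compounds named here.

Three compounds have been measured in an ADME assay on NIH3T3 cells (Mus musculus) for cytotoxicity, read by trypan blue exclusion, with a stated time of 48 h; on this read-out higher numbers stand for weaker inhibition and lower numbers for stronger inhibition:

compound 1 `Cn1cnc(C(=O)NNC(=O)COc2c(F)cc(C(=O)c3ccc(F)cc3)cc2Cl)c1`: 94200 nM
compound 2 `Cn1cnc(C(=O)NNC(=O)COc2ccc(C(=O)c3ccccc3)cc2)c1`: 98800 nM
compound 3 `Cc1ccc(C(=O)c2cc(F)c(OCC(=O)NNC(=O)c3cn(C)cn3)c(Cl)c2)cc1`: 93800 nM

In this assay compound 2 gives the highest of the three numbers, but its nearest neighbour is compound 1 and its furthest is compound 3, and both gaps lie within the scatter, so nothing separates these three compounds. Within the data shown here, the only step between compounds that differ in one place is a 1.0-fold lower number from compound 1 to compound 3 (0.00 log units; within the scatter), also within the scatter. Compound 4 `O=C(COc1ccc(C(=O)c2ccccc2)cc1)NNC(=O)c1ccc(=O)oc1` differs from compound 2 by a group of 7 heavy atoms (5 carbon, 2 oxygen; one six-membered aromatic ring with 1 hetero atom) in place of a group of 6 heavy atoms (4 carbon, 2 nitrogen; one five-membered aromatic ring with 2 hetero atoms), on a carbonyl carbon. Among the measured compounds shown here, no measured step touches that carbonyl carbon; the one measured step concerns a different place and stayed within the scatter, and every number so far sits in one narrow band. The expectation for compound 4 in this assay is therefore no step beyond the scatter, and the estimated step of a 1.0-fold lower number from compound 2 to compound 4 (0.02 log units; within the scatter) reflects that. Compound 4 is expected to give 95000 nM, within a range from 45000 nM to 200000 nM.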

Compound 4, half-maximal inhibitory concentration: 84300 nM
The estimate for compound 4 lay 1.1-fold (0.05 log units) above the measured number; the measured number falls inside the stated range.
By their numbers in this assay, from the lowest: compounds 4, 3, 1 and 2 (each within the scatter of the next).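

In this assay, putting the six-membered aromatic ring of compound 4 in place of the 1-methyl-1H-imidazol-4-yl group on the carbonyl carbon gives a 1.2-fold lower number from compound 2 to compound 4 (0.07 log units; within the scatter), so the two compounds cannot be told apart. Among these compounds, this is the first measured change at that carbonyl carbon, and it shows that this read-out does not separate these two uncharged aromatic rings, even though they differ in ring size, hetero atoms and the double bond outside the ring. No measurement at hand bears on why the result came out this way.

Going by these compounds, both groups compared on this carbonyl carbon are uncharged aromatic rings, so it remains open whether a group of another kind there, such as an amine or a carboxylic acid, would stay within the scatter. On these data alone, it also remains open whether the same exchange would give a similar result on the core of compound 1.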